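From phenyl to 3,4-dimethoxyphenyl on compound 3

The compounds below may be only part of what the source reports. "The series", "measured", "known", "first", "only" and "open" are said of these compounds alone.

Among the compounds with values here, in a functional assay on MCF7 cells (Homo sapiens) for inhibition, read by MTT assay, with a stated time of 48 h (a lower number here means a stronger inhibitor of growth, a higher number a weaker inhibitor of growth), compound 3 `Cn1cc(C2CC(c3ccccc3)=NN2C(=O)c2cccnc2)c2cc(Br)ccc21` gives 1520 nM as the lowest number so far. Compound 1 `Cc1ccc(C(=O)N2N=C(c3ccccc3)CC2c2cn(C)c3ccccc23)cn1` gives 4010 nM in this assay as the nearest number, higher than that of compound 3 by more than the scatter. Compound 2 `Cn1cc(C2CC(c3ccccc3)=NN2C(=O)c2cccnc2Cl)c2ccccc21` is reported only as a limit (> 10000 nM).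

Compound 4 `COc1ccc(C2=NN(C(=O)c3cccnc3)C(c3cn(C)c4ccc(Br)cc34)C2)cc1OC` differs from compound 3 in one place: 3,4-dimethoxyphenyl in place of phenyl on a carbon with a double bond to nitrogen with 3,4-dimethoxyphenyl in place of phenyl on a carbon with a double bond to nitrogen.

Within the data shown here, the only measured step between close pairs is an at least 2.4-fold higher number from compound 1 to compound 2 (0.39 log units; beyond the scatter) for 2-chloropyridin-3-yl in place of 6-methylpyridin-3-yl on a carbonyl carbon. That step ends at the limit of > 10000 nM in this assay, at which 1 of the 3 values shown sits, and so gives only a lower bound on its size. Among the measured compounds shown here, it also lies on the other side of the carbonyl and does not touch the place changed in compound 4, so the series holds no measured step for this change. With nothing to set a direction, no step beyond the scatter is expected, and the estimate stays anchored on compound 3 at 1520 nM with a wide range. The expected change is a 1.2-fold higher number from compound 3 to compound 4 (0.07 log units; within the scatter) in this assay as a working figure only. For compound 4 the estimated value is 1800 nM (expected range 600 nM to 6000 nM).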

Compound 4, concentration for 50% growth inhibition: 1170 nM
Compound 4: middle estimate off by 1.5-fold (0.19 log units), on the high side; low and high end bracket the measured number.
By their numbers in this assay, from the lowest: compounds 4 and 3 (each within the scatter of the next); then compound 1. At a limit, above all of these: compound 2.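

In this assay, within the data shown here, the first measured step at this position is a 1.3-fold lower number from compound 3 to compound 4 (0.11 log units; within the scatter), so phenyl and 3,4-dimethoxyphenyl on the carbon with a double bond to nitrogen cannot be told apart in this read-out. The position therefore accepts a group with more heavy atoms, with oxygen and with hydrogen-bond acceptors without a step beyond the scatter, though this rests on one pair alone and sets no trend for the position. Nothing measured here gives a reason for this result.

As far as these compounds go, whether this position stays as undemanding with a carboxylic acid, a dimethylamino group or a morpholine on the phenyl ring, or with a longer alkyl chain in place of the ring, remains open, as neither phenyl nor 3,4-dimethoxyphenyl speaks to such groups. From the compounds shown here alone, compound 2 gives > 10000 nM, which is a limit, so whether 3,4-dimethoxyphenyl would matter with its 2-chloropyridin-3-yl carbonyl also stays open.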